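Thiophen-3-yl series: methylsulfanyl to dimethylamino

The source may report more compounds than this note shows. Statements on the series, on what has been measured and on what is new or still open speak of the compounds shown alone.

Values in a functional assay on HCT-116 cells (Homo sapiens), read by MTT assay, with a stated time of 72 h; a higher number here means a weaker inhibitor, a lower number a stronger inhibitor:
- compound 1 `CSc1ncnc2c1c(-c1ccoc1)cn2[C@@H]1O[C@H](CO)[C@@H](O)[C@H]1O`: 40 nM
- compound 2 `CSc1ncnc2c1c(-c1ccsc1)cn2[C@@H]1O[C@H](CO)[C@@H](O)[C@H]1O`: > 20000 nM (a limit)
- compound 3 `CSc1ncnc2c1c(-c1ccccc1)cn2[C@@H]1O[C@H](CO)[C@@H](O)[C@H]1O`: > 20000 nM (a limit)

Compound 2 has no numerical value, and its entry of > 20000 nM is a limit. Among the measured compounds shown here, the series so far stands at the limit of > 20000 nM in this assay, at which 2 of the 3 values shown sit, so only compound 1 gives a number.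

The next structure is compound 4 `CN(C)c1ncnc2c1c(-c1ccsc1)cn2[C@@H]1O[C@H](CO)[C@@H](O)[C@H]1O`, which keeps the thiophen-3-yl group of compound 2. The change is dimethylamino in place of methylsulfanyl on an aromatic carbon.

The measured steps all concern the other substituent, and all three compounds carry methylsulfanyl. Thiophen-3-yl in place of furan-3-yl gave an at least 500-fold higher number from compound 1 to compound 2 (2.69 log units; beyond the scatter). Phenyl in place of furan-3-yl gave an at least 500-fold higher number from compound 1 to compound 3 (2.69 log units; beyond the scatter). Between the two limits there is a step that the two limits leave unreadable from compound 2 to compound 3. For the measured compounds named here, no measured step replaces methylsulfanyl, so the size of this change rests on no direct precedent.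

The large steps show how much the aromatic group matters here, and compound 4 retains the group of compound 2, whose entry is > 20000 nM. In this assay the expected outcome is a number no higher from compound 2 to compound 4 (the limit leaves the size open), with no clear step in either direction. The estimated value for compound 4 is 20000 nM, with an expected range of 5000 nM to 40000 nM.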

Compound 4, half-maximal inhibitory concentration: > 20000 nM
Compound 4 ended at the assay's limit; the forecaster's own chance of this, stated with the estimate: 70%; the middle value sits exactly at the limit.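

Compound 4 gives > 20000 nM in this assay, which is a limit and not a number. Compound 2 also stands at a limit, so dimethylamino in place of methylsulfanyl yields no readable step between compound 2 and compound 4: the limit of > 20000 nM in this assay, at which 3 of the 4 values shown sit.

The compounds shown leave open how this change acts alongside furan-3-yl, the group of compound 1, the only compound here with a number.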